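The compounds below may be only part of what the source reports. "The series", "measured", "known", "first", "only" and "open" are said of these compounds alone.

In a functional assay on MCF7 cells (Homo sapiens) for antiproliferative activity, read by MTT assay, with a stated time of 48 h (a higher number here means a weaker inhibitor, a lower number a stronger inhibitor), compound 3 `COc1cc(/C=C/C(C)=O)ccc1OCc1cn(-c2ccccc2)nn1`, which carries a plain phenyl on the aromatic nitrogen, gives > 100000 nM, and this is a limit of the assay and not a number. The change under consideration is hydroxy in place of hydrogen on an aromatic carbon, ortho to a large group, or phenyl to 2-hydroxyphenyl. It leads to compound 4 `COc1cc(/C=C/C(C)=O)ccc1OCc1cn(-c2ccccc2O)nn1`.

Two measured relatives bear on this change. Compound 1 `COc1cc(/C=C/C(C)=O)ccc1OCc1cn(-c2c(Cl)cccc2Cl)nn1`, with 2,6-dichlorophenyl, gives 26600 nM. Compound 2 `COc1cccc(-n2cc(COc3ccc(/C=C/C(C)=O)cc3OC)nn2)c1`, with 3-methoxyphenyl, gives 1800 nM. Going to the plain phenyl raises the number in both cases: an at least 3.7-fold higher number from compound 1 to compound 3 (0.57 log units; beyond the scatter) and an at least 55-fold higher number from compound 2 to compound 3 (1.74 log units; beyond the scatter). Among these three compounds, each substituted ring therefore reads lower than the plain phenyl, and none goes against this. The choice of substituent also counts, as a 15-fold lower number from compound 1 to compound 2 (1.17 log units; beyond the scatter) shows. Among the compounds with values here, no hydroxy compound has been measured yet, so the transfer to compound 4 is loose, and a result at the limit again remains possible.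

A move to a lower number is expected, of modest to large size, with the estimate being an at least 3.3-fold lower number from compound 3 to compound 4 (0.52 log units; beyond the scatter). For compound 4 the estimated value is 30000 nM, with an expected range of 5000 nM to 100000 nM.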

Compound 4, half-maximal inhibitory concentration: > 100000 nM
Compound 4 gave a limit, no number; the forecaster's own chance of this, stated with the estimate: 30%; at least 3.3-fold (0.52 log units) between middle value and limit.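

In this assay compound 4 gives > 100000 nM, which is a limit of the assay and not a number. A substituent on the phenyl ring therefore does not by itself bring a compound of this series clear of the limit, and compound 4 goes against the earlier picture, in which compound 1 and compound 2 each read lower than the plain phenyl of compound 3; the step between compound 3 and compound 4 itself cannot be read, because both compounds sit at the same limit: the limit of > 100000 nM in this assay, at which 2 of the 4 values shown sit. The identity of the substituent and its place on the ring weigh heavily in this small set, with an at least 55-fold higher number from compound 2 to compound 4 (1.74 log units; beyond the scatter) and an at least 3.7-fold higher number from compound 1 to compound 4 (0.57 log units; beyond the scatter).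

Whether hydroxy, ortho to a large group, changes activity at all remains unresolved, since any difference from hydrogen lies beyond the range of the assay. Also open, as far as these compounds go, is whether the weak reading of compound 4 belongs to the hydroxy group or to its place, and how methoxy, an amine or a carboxylic acid would read on the same carbon.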